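This account rests on a few compounds, and the source may have more. Where it says the series, first, only, none or still open, it means among the compounds named here.

Measured compounds in an assay on HEK293 cells for antagonist activity at transient receptor potential M8 protein (Canis lupus familiaris), read by fluorescence and calcium flux, with a stated time of 5 min; a higher number here means a weaker inhibitor, a lower number a stronger inhibitor:
Compound 1 `O=C(C(Nc1ccccc1)c1ccc(C(F)(F)F)cc1)N1CCC[C@H]1c1ccccc1Cl` gives 41 nM.
Compound 2 `O=C(C(Nc1ccccc1F)c1ccc(C(F)(F)F)cc1)N1CCCC1c1ccccc1F` gives 7 nM.
Compound 3 `O=C(C(Nc1ccccc1F)c1ccc(C(F)(F)F)cc1)N1CCCC1c1cccc(F)c1` gives 9 nM.

Compound 3 stands second highest of these three numbers; its value lies within the scatter of compound 2 and is clearly separated from compound 1. Among the measured compounds shown here, the single step measured in one place is a 1.3-fold higher number from compound 2 to compound 3 (0.11 log units; within the scatter), an exchange of one fluorophenyl group for another at the same saturated ring carbon. Compound 4 `O=C(C(Nc1ccccc1F)c1ccc(C(F)(F)F)cc1)N1CCCC1c1ccc(F)cc1` differs from compound 3 in the same fashion: 4-fluorophenyl in place of 3-fluorophenyl on a saturated ring carbon. Because that measured exchange gave a 1.3-fold higher number from compound 2 to compound 3 (0.11 log units; within the scatter), no shift beyond the scatter is expected here. The expected step is a 1.1-fold higher number from compound 3 to compound 4 (0.05 log units; within the scatter), and compound 4 is estimated at 10 nM, between 4 nM and 25 nM.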

Compound 4, half-maximal inhibitory concentration: 37 nM
Compound 4: the middle estimate sits 3.7-fold (0.57 log units) below what was measured, outside the stated range (above it).
By their numbers in this assay, from the lowest: compounds 2 and 3 (each within the scatter of the next); then compounds 4 and 1 (each within the scatter of the next).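

Both a 4.1-fold higher number from compound 3 to compound 4 (0.61 log units; beyond the scatter) and a 5.3-fold higher number from compound 2 to compound 4 (0.72 log units; beyond the scatter) follow in this assay from the change to 4-fluorophenyl on this saturated ring carbon. The place of the fluorine on this phenyl group can therefore matter here, which the earlier pair of 2-fluorophenyl and 3-fluorophenyl did not show. Nothing available explains this shift. On these data alone, it stays open whether an amine or a methoxy group in place of that fluorine would give a lower or a higher number, and whether the same sensitivity would hold on a different core.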